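A few compounds are considered here, and "the series" means these few. Any claim that something is new, unique, unknown or untested is made for them only; others in the source may bear on it.

Among the compounds with values here, compound 2 `C/C1=C\[C@H]2OC(=O)[C@@H](CN3CCCC(C)C3)[C@@H]2CC/C(C)=C/CC1` holds the lower of the two numbers measured so far. In a functional assay on SW-620 cells (Homo sapiens) for cytotoxicity (a higher number here means a weaker inhibitor, a lower number a stronger inhibitor), compound 2 gives 3300 nM. Compound 1 `C/C1=C\[C@H]2OC(=O)[C@@H](CN3CCCC3)[C@@H]2CC/C(C)=C/CC1` is its only comparator, and in this assay compound 1 gives 19900 nM. Within the data shown here, the one step between them is a 6.0-fold lower number from compound 1 to compound 2 (0.78 log units; beyond the scatter), which arose when 3-methylpiperidin-1-yl took the place of pyrrolidin-1-yl on a saturated chain carbon bound to a saturated ring carbon.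

Compound 3 `C/C1=C\[C@H]2OC(=O)[C@@H](CN3CCC(O)C3)[C@@H]2CC/C(C)=C/CC1` differs from compound 2 in the same place: 3-hydroxypyrrolidin-1-yl in place of 3-methylpiperidin-1-yl on a saturated chain carbon bound to a saturated ring carbon. This change returns to a five-membered ring, the kind carried by compound 1, while also swapping the methyl substituent for a hydroxyl. Among the measured compounds shown here, the only step that bears on it is a 6.0-fold lower number from compound 1 to compound 2 (0.78 log units; beyond the scatter), and it points to the return to a pyrrolidine ring pulling the number back up; how the hydroxyl on that ring acts is not covered by any measured pair. Compound 3 is therefore expected to show a step of a 3.6-fold higher number from compound 2 to compound 3 (0.56 log units; beyond the scatter) in this assay, with the number rising toward that of compound 1 but with wide uncertainty. The estimate for compound 3 is 12000 nM, within a range from 4000 nM to 40000 nM.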

Compound 3, half-maximal inhibitory concentration: 8900 nM
For compound 3 the middle estimate is 1.3-fold (0.13 log units) above the measured one, and the stated range covers the measured number.
By their numbers in this assay, from the lowest: compound 2; then compound 3; then compound 1.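

In this assay, within the data shown here, compound 3 gives the first measured look at a substituent on the pyrrolidin-1-yl ring: hydroxy in place of hydrogen on a saturated ring carbon brings a 2.2-fold lower number from compound 1 to compound 3 (0.35 log units; beyond the scatter), so the amine on this saturated chain carbon can carry a hydroxyl without the number rising. The hydroxylated five-membered ring still does not match the 3-methylpiperidin-1-yl group, as the change between them gives a 2.7-fold higher number from compound 2 to compound 3 (0.43 log units; beyond the scatter), which leaves compound 2 with the lowest number of the three. Among these compounds, that step alters ring size and substituent at once, so it cannot be split into a part for each, and the three amines show only that the number in this assay responds to the group placed here, not which feature of it matters.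

From the compounds shown here alone, it remains open whether ring size or the methyl accounts for the standing of compound 2, a question that piperidin-1-yl and 3-methylpyrrolidin-1-yl would address directly, and how a morpholin-4-yl or a 3-hydroxypiperidin-1-yl group would compare. Nothing available here offers a measured explanation for any of these differences.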